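Shortening the alkynyl chain on the shared core

The compounds below may be only part of what the source reports. "The series", "measured", "known", "first", "only" and "open" are said of these compounds alone.

Compound 1 `CCCC/C=C\c1cn([C@H]2C[C@H](O)[C@@H](CO)O2)c(=O)[nH]c1=O` and compound 2 `CCCC#Cc1cn([C@H]2C[C@H](O)[C@@H](CO)O2)c(=O)[nH]c1=O` share one core and differ at a single aromatic carbon. In a functional assay on L1210 cells (Mus musculus) (a lower number here means a stronger inhibitor, a higher number a weaker inhibitor), compound 1 gives 361 ug/mL. For compound 2 the assay reports only a limit, > 1000 ug/mL, so compound 2 stands at the weaker end of the two values shown, as the record the limit of > 1000 ug/mL in this assay, at which 1 of the 2 values shown sits, states. The measured step of an at least 2.7-fold higher number from compound 1 to compound 2 (0.44 log units; beyond the scatter) concerns pent-1-yn-1-yl in place of hex-1-en-1-yl, not the length of an alkynyl chain. Compound 3 `CC#Cc1cn([C@H]2C[C@H](O)[C@@H](CO)O2)c(=O)[nH]c1=O` is the next compound, and relative to compound 2 the change is hydrogen in place of ethyl on a saturated chain carbon bound to a triple-bonded carbon. Going by the values given here, no measured step covers a shortening of this kind, so the data give neither direction nor size for it in this assay. Because compound 2 sits at the limit > 1000 ug/mL, any number for compound 3 can only be set loosely. Compound 3 is expected to stay near that limit, estimated at 1000 ug/mL with a range from 400 ug/mL to 3000 ug/mL. The step of a number no higher from compound 2 to compound 3 (the limit leaves the size open) is therefore expected to lie within the scatter.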

Compound 3, concentration for 50% inhibition: 164 ug/mL
The estimate for compound 3 lay 6.1-fold (0.79 log units) above the measured number, outside the stated range (below it).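

In this assay the shortening of pent-1-yn-1-yl to prop-1-yn-1-yl gives an at least 6.0-fold lower number from compound 2 to compound 3 (0.78 log units; beyond the scatter) and shows that the length of the alkynyl chain at this aromatic carbon matters, which the earlier pair could not show. The alkynyl compounds also do not fall on one side of hex-1-en-1-yl: the step of an at least 2.7-fold higher number from compound 1 to compound 2 (0.44 log units; beyond the scatter) points towards a higher number, while the step of a 2.2-fold lower number from compound 1 to compound 3 (0.34 log units; beyond the scatter) points towards a lower one, so the direction against hex-1-en-1-yl depends on the alkynyl group's length in these three compounds. The shortening step has a minimum size but no known full size, as compound 2 is recorded only as a limit: the limit of > 1000 ug/mL in this assay, at which 1 of the 3 values shown sits.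

On these data alone, whether the number keeps falling with ethynyl, the shorter group with hydrogen on the triple-bonded carbon, or rises again with a longer chain such as hex-1-yn-1-yl, remains open. As far as these compounds go, it is also open how a hydroxyl or an amine at the end of the prop-1-yn-1-yl chain would shift the number in this assay.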